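Sugar-Linked Triazoles: Does an Acetamido Swap Matter?

This account rests on a few compounds, and the source may have more. Where it says the series, first, only, none or still open, it means among the compounds named here.

Measured so far:
compound 1 `CC(=O)OC[C@H]1O[C@@H](n2nncc2CCl)[C@H](OC(C)=O)[C@@H](OC(C)=O)[C@@H]1OC(C)=O`, in a functional assay on HeLa cells (Homo sapiens), read by colorimetric assay, with a stated time of 72 h (on this read-out lower numbers stand for an effect already at smaller amounts and higher numbers for an effect only at larger amounts of compound), compound 1 gives 25 ug/mL;
compound 2 `CC(=O)N[C@@H]1[C@@H](OC(C)=O)[C@H](OC(C)=O)[C@@H](COC(C)=O)O[C@H]1n1nncc1CCl`, in this assay compound 2 gives 25 ug/mL;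
compound 3 `CC(=O)OC[C@H]1O[C@@H](n2nnc(CO)c2CO)[C@H](OC(C)=O)[C@@H](OC(C)=O)[C@@H]1OC(C)=O`, for which this assay reports only a limit, > 100 ug/mL.

The first pair share a core and differ by acetamido in place of acetoxy on a saturated ring carbon; this gave no change at the digits printed from compound 1 to compound 2 (within the scatter). Compound 3 differs from compound 1 by 4,5-bis(hydroxymethyl)-1H-1,2,3-triazol-1-yl in place of 5-(chloromethyl)-1H-1,2,3-triazol-1-yl on a saturated ring carbon, with an at least 4.0-fold higher number from compound 1 to compound 3 (0.60 log units; beyond the scatter), the value sitting at the limit of > 100 ug/mL in this assay, at which 1 of the 3 values shown sits.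

Compound 4 `CC(=O)N[C@@H]1[C@@H](OC(C)=O)[C@H](OC(C)=O)[C@@H](COC(C)=O)O[C@H]1n1nnc(CO)c1CO` is not yet measured. It differs from compound 3 by acetamido in place of acetoxy on a saturated ring carbon. This is the same kind of change as that from compound 1 to compound 2, though the surroundings differ: the carbon now sits next to the ring atom that bears a 4,5-bis(hydroxymethyl)-1H-1,2,3-triazol-1-yl group rather than a 5-(chloromethyl)-1H-1,2,3-triazol-1-yl group.

Because no change at the digits printed from compound 1 to compound 2 (within the scatter) showed no shift, the expected step is a step that the limit leaves unreadable from compound 3 to compound 4. Compound 4 is therefore estimated at 150 ug/mL in this assay, most likely again reported only as a limit.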

Compound 4, concentration for half-maximal effect: > 100 ug/mL
Compound 4 gave a limit, no number (the forecaster's own chance of this, stated with the estimate: 85%); the middle value is on the limit's open side.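

In this assay, placing 4,5-bis(hydroxymethyl)-1H-1,2,3-triazol-1-yl in place of 5-(chloromethyl)-1H-1,2,3-triazol-1-yl on the acetamido compound gives an at least 4.0-fold higher number from compound 2 to compound 4 (0.60 log units; beyond the scatter). Going by these compounds, the change therefore points the same way on both cores, but its size cannot be compared between them: the same change on two cores in this assay, an at least 4.0-fold higher number (0.60 log units; beyond the scatter) from compound 1 to compound 3 and an at least 4.0-fold higher number (0.60 log units; beyond the scatter) from compound 2 to compound 4; the limit leaves it open whether they differ Compound 4 gives only a limit, > 100 ug/mL, and the step from compound 3 cannot be read, so it stays unknown whether acetamido in place of acetoxy again leaves the read-out unchanged on this core.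

The compounds shown leave open whether losing the chloromethyl group or gaining the hydroxymethyl groups matters more. A single hydroxymethyl group or an aminomethyl group on the triazole could help separate these two possibilities.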